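This account rests on a few compounds, and the source may have more. Where it says the series, first, only, none or still open, it means among the compounds named here.

Measured so far in a functional assay on A549 cells (Homo sapiens) for cytotoxicity, read by MTT assay, with a stated time of 48 h; on this read-out lower numbers stand for stronger inhibition and higher numbers for weaker inhibition:

compound 1, `COc1ccc(-c2nc3ccccn3c2C(=O)/C=C\Nc2cnc3ccccc3c2)cc1`: 1050 nM
compound 2, `O=C(/C=C\Nc1cnc2ccccc2c1)c1c(-c2ccccc2)nc2ccccn12`: 1750 nM
compound 3, `COc1cc(N/C=C\C(=O)c2c(-c3ccc(Cl)cc3)nc3ccccn23)cc(OC)c1OC`: 1140 nM

Compound 1 and compound 2 differ by hydrogen in place of methoxy on an aromatic carbon, and this assay moved by a 1.7-fold higher number from compound 1 to compound 2 (0.22 log units; within the scatter). Compound 4, `COc1cc(N/C=C\C(=O)c2c(-c3ccc(Cl)cc3)nc3ccccn23)cc(OC)c1`, is not yet measured; it differs from compound 3 by hydrogen in place of methoxy on an aromatic carbon. This is the same kind of change as that from compound 1 to compound 2, not the same: here the place is also ortho to two methoxy groups (2 heavy atoms each), while in the earlier pair it is para to a large group only. The difference between the two cores is not broken down here.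

For compound 4 a step of about a 1.5-fold higher number from compound 3 to compound 4 (0.17 log units; within the scatter) is expected, resting on the earlier pair, where the loss of the methoxy gave a 1.7-fold higher number from compound 1 to compound 2 (0.22 log units; within the scatter); the surroundings of the place differ, so the expectation is held loosely. Compound 4 is estimated at 1700 nM, likely between 800 nM and 3600 nM.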

Compound 4, half-maximal inhibitory concentration: 9900 nM
Compound 4: the middle estimate sits 5.8-fold (0.77 log units) below what was measured; measured number above the stated range.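

In this assay, the loss of the methoxy group now gives a step beyond the scatter, with an 8.7-fold higher number from compound 3 to compound 4 (0.94 log units; beyond the scatter). The size of this change does not carry from one core to the other in these two pairs: the same change on two cores in this assay, a 1.7-fold higher number (0.22 log units; within the scatter) from compound 1 to compound 2 and an 8.7-fold higher number (0.94 log units; beyond the scatter) from compound 3 to compound 4, 5.2-fold (0.72 log units) apart, beyond the scatter of two such steps. Among the compounds shown here, this does not show which structural difference sets the size of the step, as each core supplies only one pair, and the two pairs differ in more than one feature around the place of change.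

Left open is whether a hydroxy group or a fluorine in that place on compound 4 would restore the level of compound 3. Also open, going by these compounds, is how the step would look on the core of compound 1 with other groups on the ring carrying the methoxy.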